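A Methyl Added on the Chain of Compound 2

The compounds below may be only part of what the source reports. "The series", "measured", "known", "first", "only" and "open" are said of these compounds alone.

Compound 1 `O=C1N(Cc2ccc(COc3ccc(-c4ccc(Cl)cc4)cc3)cc2)CCN1c1ccncc1`: > 1250 nM
Compound 2 `CC(CCCN1CCN(c2ccncc2)C1=O)COc1ccc(-c2ccc(Cl)cc2)cc1`: > 25000 nM
Compound 3 `O=C1N(CCC(CCOc2ccc(-c3ccc(Cl)cc3)cc2)c2ccccc2)CCN1c1ccncc1`: > 25000 nM

In an ADME assay on cells (Homo sapiens) for cytotoxicity (a lower number here means that less compound is tolerated, a higher number that more compound is tolerated), compound 2 gives > 25000 nM, which is a limit of the assay and not a number. Compound 3 likewise gives > 25000 nM, again a limit, so that these two share the same boundary (the limit of > 25000 nM in this assay, at which 2 of the 3 values shown sit). Compound 1 stops at a different boundary, its > 1250 nM being a limit as well (the limit of > 1250 nM in this assay, at which 1 of the 3 values shown sits). Compound 2 therefore stands at the upper boundary of what the assay reports, together with compound 3, and nothing in the shown numbers ranks it against compound 1 beyond the fact that the two boundaries differ.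

Compound 4 `CC(C)(CCCN1CCN(c2ccncc2)C1=O)COc1ccc(-c2ccc(Cl)cc2)cc1` differs from compound 2 by methyl in place of hydrogen on a saturated chain carbon bound to three saturated chain carbons. For the measured compounds named here, no pair of measured compounds differs in one place, so no measured step shows what such a change does in this assay. The expected step that the limit leaves unreadable from compound 2 to compound 4 is none beyond the scatter, since compound 2 already sits at the boundary > 25000 nM and the change adds only a methyl. Compound 4 is therefore expected at 30000 nM, within a range from 15000 nM to 100000 nM, and most likely reported again as a limit rather than a number.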

Compound 4, half-maximal cytotoxic concentration: > 25000 nM
Compound 4 gave a limit, no number; the forecaster's own chance of this, stated with the estimate: 85%; the middle value does not contradict the limit.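

In this assay compound 4 gives > 25000 nM, which is a limit and not a number. Compound 2 stands at the same limit, so no step can be read between compound 2 and compound 4. The compounds shown leave open at what concentration any of them becomes cytotoxic, and whether the added methyl changes that concentration at all.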